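What flipping one double bond might do to compound 1

The compounds below may be only part of what the source reports. "The series", "measured", "known", "first", "only" and "open" are said of these compounds alone.

In a functional assay on T98G cells (Homo sapiens) for cytotoxicity, read by MTT assay, with a stated time of 48 h (on this read-out lower numbers stand for stronger inhibition and higher numbers for weaker inhibition), compound 1 `C/C(=N\NC(=S)Nc1ccc(Cl)cc1)c1ccccn1` gives 5.9 nM. Compound 3 `CC(=NNC(=S)Nc1ccccc1[N+](=O)[O-])c1ccccn1` gives 6.6 nM, level with compound 1 within the usual scatter. Compound 2 `C/C(=N\NC(=S)Nc1ccc(I)cc1)c1ccccn1` gives 64 nM. Compound 1 therefore sits at the low end of these numbers, alongside compound 3.

Compound 4 `C/C(=N/NC(=S)Nc1ccc(Cl)cc1)c1ccccn1` has not yet been measured. Its difference from compound 1 is the two compounds have the same atoms and bonds and differ only in configuration as drawn: 1 of 1 stereo elements differ; a double bond is drawn E in compound 1 and Z in compound 4. The atoms and bonds stay the same, and only the way the double bond is drawn changes, from E to Z.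

For the measured compounds named here, the only measured step, an 11-fold higher number from compound 1 to compound 2 (1.04 log units; beyond the scatter), is large, but it puts iodo in place of chloro on an aromatic carbon. Going by the values given here, it warns that one edit can move the number, yet it does not test configuration, and no measured pair does. The expected step is a 1.7-fold higher number from compound 1 to compound 4 (0.23 log units; within the scatter), which means no clear change is expected, although the margin must stay wide. For compound 4 the estimated value is 10 nM, with an expected range from 3 nM to 60 nM.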

Compound 4, half-maximal inhibitory concentration: 5.9 nM
Estimate against measurement, compound 4: 1.7-fold (0.23 log units) above, within the range that was stated.
By their numbers in this assay, from the lowest: compounds 1, 4 and 3 (each within the scatter of the next); then compound 2.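

Changing the way the double bond is drawn, from E to Z, gives no change at the digits printed from compound 1 to compound 4 (within the scatter) in this assay. For the compounds shown here, this is the first direct test of configuration at this double bond, and the comparison is a clean one: the fact that compounds 1 and 4 differ only in the configuration as drawn. Until now, the only measured step was a change of atom on the aromatic ring, an 11-fold higher number from compound 1 to compound 2 (1.04 log units; beyond the scatter), so the series had shown one edit that moves the number strongly and now shows one that leaves it in place.

The compounds shown cannot say whether the same flip would leave the number in place for compound 2, which carries iodo in place of chloro, since this result comes from a single pair. They also leave open what an amine or a carboxylic acid in place of chloro would do to the number.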